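Ether substituent change from compound 2 to compound 4

The compounds below may be only part of what the source reports. "The series", "measured", "known", "first", "only" and "open" are said of these compounds alone.

compound 1 `C=CCOc1ccc2c(=O)c(-c3cc(OC)c(OC)cc3OC)coc2c1`: 5900 nM
compound 2 `COc1cc(OC)c(-c2coc3cc(OCc4ccc(F)cc4)ccc3c2=O)cc1OC`: 3200 nM
compound 3 `COc1cc(OC)c(-c2coc3cc(OCc4cccc(Cl)c4)ccc3c2=O)cc1OC`: > 10000 nM, a limit of the assay

In a functional assay on U-251 cells (Homo sapiens) for antiproliferative activity, read by MTT assay, with a stated time of 24 h (a lower number here means a stronger inhibitor, a higher number a weaker inhibitor), compound 2 gives 3200 nM, the lower of the two numbers, although a 1.8-fold lower number from compound 1 to compound 2 (0.27 log units; within the scatter) stays within the scatter. Compound 3 sits at a limit (the limit of > 10000 nM in this assay, at which 1 of the 3 values shown sits). Compound 4 `COc1cc(OC)c(-c2coc3cc(OCc4ccccc4Cl)ccc3c2=O)cc1OC` differs from compound 2 by 2-chlorophenyl in place of 4-fluorophenyl on a saturated chain carbon bound to an oxygen on an aromatic ring. The step that bears on this is an at least 3.1-fold higher number from compound 2 to compound 3 (0.49 log units; beyond the scatter), with an at least 1.6-fold higher number from compound 1 to compound 3 (0.22 log units; that floor lies within the scatter) pointing the same way; both place a chlorophenyl at this position beyond compound 2, though compound 3 holds the chlorine elsewhere on the ring. A modest rise in the number is therefore expected, with a fair chance of another limit. Compound 4 is expected near 7000 nM, between 2500 nM and 20000 nM. The expected step is a 2.2-fold higher number from compound 2 to compound 4 (0.34 log units; beyond the scatter).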

Compound 4, half-maximal inhibitory concentration: > 10000 nM
Compound 4: only a limit was reported; the forecaster's own chance of this, stated with the estimate: 35%; at least 1.4-fold (0.15 log units) between middle value and limit.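

The change to 2-chlorophenyl gives an at least 3.1-fold higher number from compound 2 to compound 4 (0.49 log units; beyond the scatter), so the rise seen with compound 3 is not tied to a single chlorine placement on this ring. Against the vinyl of compound 1, the change gives an at least 1.6-fold higher number from compound 1 to compound 4 (0.22 log units; that floor lies within the scatter), and that pair supports no firm order. The step between compound 3 and compound 4 cannot be read, since each value is a limit: the limit of > 10000 nM in this assay, at which 2 of the 4 values shown sit.

Open, as far as these compounds go, is whether 4-chlorophenyl would read with compound 2 or at the limit, separating the halogen from its placement. Also open, from the compounds shown here alone, is how a ring carrying an amine or a carboxylic acid would read here.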